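A few compounds are considered here, and "the series" means these few. Any claim that something is new, unique, unknown or untested is made for them only; others in the source may bear on it.

Measured in a functional assay on U-937 cells (Homo sapiens) for cytotoxicity, read by MTT assay, with a stated time of 24 h; a lower number here means a stronger inhibitor, a higher number a weaker inhibitor:
Compound 1 `Brc1ccc(Oc2cc(Br)cc(Br)c2OCCCCCN2CCN(c3ccccc3)CC2)c(Br)c1`: 42.5 ug/mL
Compound 2 `COc1ccccc1N1CCN(CCCCCOc2c(Br)cc(Br)cc2Oc2ccc(Br)cc2Br)CC1`: 37.5 ug/mL

Compound 2, at 37.5 ug/mL, cannot be told apart from compound 1, at 42.5 ug/mL. Compound 3 `CC(C)(C)OC(=O)N1CCN(CCCCCOc2c(Br)cc(Br)cc2Oc2ccc(Br)cc2Br)CC1` has not yet been measured. It keeps the rest of compound 2 and differs as follows: tert-butoxycarbonyl in place of 2-methoxyphenyl on an amine nitrogen in a ring. In words, this is tert-butoxycarbonyl in place of 2-methoxyphenyl on an amine nitrogen in a ring. Going by the values given here, only one measured step bears on this, a 1.1-fold lower number from compound 1 to compound 2 (0.05 log units; within the scatter), which lies within the scatter. Among the compounds with values here, that step, methoxy in place of hydrogen on an aromatic carbon, is a much smaller change, and no measured compound shows the replacement itself. A step beyond the scatter in this assay is therefore not expected, though this rests on thin evidence. The expected change is a 1.1-fold higher number from compound 2 to compound 3 (0.03 log units; within the scatter). For compound 3 the estimated value is 40 ug/mL, with an estimated range of 18 ug/mL to 85 ug/mL.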

Compound 3, half-maximal inhibitory concentration: 35.5 ug/mL
Compound 3: middle estimate off by 1.1-fold (0.05 log units), on the high side; measured number inside the range.
By their numbers in this assay, from the lowest: compounds 3, 2 and 1 (each within the scatter of the next).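

In this assay, the amine nitrogen of the six-membered non-aromatic ring now carries tert-butoxycarbonyl, which has no ring, and the replacement of 2-methoxyphenyl gives a 1.1-fold lower number from compound 2 to compound 3 (0.02 log units; within the scatter) and stays within the scatter. The replacement of phenyl gives a 1.2-fold lower number from compound 1 to compound 3 (0.08 log units; within the scatter) and also stays within the scatter, so at this position, across these three compounds, a carbamate-bearing group without a ring cannot be told apart from either aromatic group, something the earlier methoxy step on the aromatic ring could not show. Nothing measured here offers an explanation for this result.

The compounds shown leave open whether a hydrogen on this ring nitrogen, an acetyl group or a benzyl group would also stay within the scatter. They also leave open how a shorter chain would read in this assay.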